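The compounds below may be only part of what the source reports. "The series", "measured", "known", "first", "only" and "open" are said of these compounds alone.

Measured so far:
Compound 1 `CC(=O)OC[C@H]1O[C@@H](n2cc(CN3C(=O)/C(=C\c4ccc(C)cc4)c4ccccc43)nn2)[C@H](OC(C)=O)[C@@H](OC(C)=O)[C@@H]1OC(C)=O`: in a functional assay on HeLa cells (Homo sapiens) for cytotoxicity, read by sulforhodamine B assay, with a stated time of 48 h (on this read-out lower numbers stand for stronger inhibition and higher numbers for weaker inhibition), compound 1 gives > 100000 nM, a limit of the assay rather than a number.
Compound 2 `CC(=O)OC[C@H]1O[C@@H](n2cc(CN3C(=O)/C(=C\c4ccc(N(C)C)cc4)c4ccccc43)nn2)[C@H](OC(C)=O)[C@@H](OC(C)=O)[C@@H]1OC(C)=O`: in this assay compound 2 gives 25000 nM.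

Within the data shown here, compound 2 therefore holds the only measured number in this assay; the remaining value is a limit (the limit of > 100000 nM in this assay, at which 1 of the 2 values shown sits). Both compounds share one core and differ only in the aryl group on a double-bonded chain carbon. The step of an at least 4.0-fold lower number from compound 1 to compound 2 (0.60 log units; beyond the scatter) shows that exchanging this aryl group can move the number by at least that much. Compound 3 `CC(=O)OC[C@H]1O[C@@H](n2cc(CN3C(=O)/C(=C\c4ccc5ccccc5c4)c4ccccc43)nn2)[C@H](OC(C)=O)[C@@H](OC(C)=O)[C@@H]1OC(C)=O` carries yet another aryl group there: naphthalen-2-yl in place of 4-(dimethylamino)phenyl on a double-bonded chain carbon bound to a double-bonded ring carbon. Among the measured compounds shown here, the only measured step that bears on this change is an at least 4.0-fold lower number from compound 1 to compound 2 (0.60 log units; beyond the scatter), in which a dimethylamino group entered; here that group leaves and a second six-membered aromatic ring of carbon only enters, with 0 hydrogen-bond acceptors, so the direction of that step is no direct guide. Compound 1 sits at a limit. A step back toward weaker inhibition is thus as plausible as a modest gain. Compound 3 is expected to give about 60000 nM, between 15000 nM and 200000 nM, in this assay. The expected step is a 2.4-fold higher number from compound 2 to compound 3 (0.38 log units; beyond the scatter).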

Compound 3, half-maximal inhibitory concentration: > 100000 nM
Compound 3: only a limit was reported; the forecaster's own chance of this, stated with the estimate: 40%; middle value at least 1.6-fold (0.22 log units) away from the limit.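

Putting naphthalen-2-yl in place of 4-(dimethylamino)phenyl on a double-bonded chain carbon bound to a double-bonded ring carbon gives an at least 4.0-fold higher number from compound 2 to compound 3 (0.60 log units; beyond the scatter) in this assay, so a second six-membered aromatic ring at this place does not keep the number seen with compound 2, and among the three aryl groups shown, only 4-(dimethylamino)phenyl gives a measured number. Compound 3 gives > 100000 nM, which is a limit of the assay and not a number. The step between compound 1 and compound 3 cannot be read, because both compounds sit at the same limit: the limit of > 100000 nM in this assay, at which 2 of the 3 values shown sit.

From the compounds shown here alone, with a single measured number, it remains open whether the dimethylamino group itself matters or whether a plain amino group, a methoxy group or a morpholine ring at the same place would also give a measured number. Going by these compounds, how far the true values of compound 1 and compound 3 lie beyond the limit also remains open, so these two compounds cannot be placed in order.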